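The source may report more compounds than this note shows. Statements on the series, on what has been measured and on what is new or still open speak of the compounds shown alone.

Compound 2 `COc1cc(-c2nnc(SCC(=O)c3ccc(F)cc3)n2N)cc(OC)c1OC` carries a fluoro group on the phenyl ring of the side chain; in a functional assay on HepG2 cells (Homo sapiens) for antiproliferative activity, read by MTT assay, with a stated time of 48 h (a higher number here means a weaker inhibitor, a lower number a stronger inhibitor), compound 2 gives 90400 nM, the higher of the two numbers measured here. Among the compounds with values here, the only measured neighbour is compound 1 `COc1cc(-c2nnc(SCC(=O)c3ccccc3)n2N)cc(OC)c1OC`, which in this assay gives 7800 nM; the one-point change from compound 1 to compound 2, fluoro in place of hydrogen on an aromatic carbon, gave a 12-fold higher number from compound 1 to compound 2 (1.06 log units; beyond the scatter). Compound 3 `COc1cc(-c2nnc(SCC(=O)c3ccc(F)c(F)c3)n2N)cc(OC)c1OC` goes one step further: fluoro in place of hydrogen on an aromatic carbon. That single measured step bears on it only loosely, since the new fluoro enters a different position, ortho to the existing fluoro group. A further rise in the number, smaller than the first, or none beyond the scatter, is the expectation for compound 3, estimated as a 1.2-fold higher number from compound 2 to compound 3 (0.09 log units; within the scatter). Compound 3 is therefore expected to give about 110000 nM, within 35000 nM to 350000 nM.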

Compound 3, half-maximal inhibitory concentration: > 100000 nM
Compound 3: a limit, no number; the forecaster's own chance of this, stated with the estimate: 15%; the middle value does not contradict the limit.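

In this assay, compound 3 gives > 100000 nM, which is a limit and not a number: the limit of > 100000 nM in this assay, at which 1 of the 3 values shown sits.

From the compounds shown here alone, the fluoro group entering ortho to a fluoro group gives an at least 1.1-fold higher number from compound 2 to compound 3 (0.04 log units; that floor lies within the scatter), so the size of this step stays unknown, and it cannot be said whether the second fluoro changes anything. The 3,4-difluorophenyl group in place of phenyl gives an at least 12-fold higher number from compound 1 to compound 3 (1.10 log units; beyond the scatter), which shows that adding the second fluoro does not bring the number back towards that of the phenyl compound.

The compounds shown leave open whether the rise belongs to fluoro itself or would follow any group placed on this ring. A chlorine, a methoxy group or an amine in place of the fluoro would separate these readings.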